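Swapping Bromines for Methyls on the Aryl Ring

A few compounds are considered here, and "the series" means these few. Any claim that something is new, unique, unknown or untested is made for them only; others in the source may bear on it.

Measured so far:
- Compound 1, `Cc1ccccc1-c1nc(CN2CCC(C(=O)NCCCN3[C@H](C)CCC[C@@H]3C)CC2)c(C)o1`: 21300 nM
- Compound 2, `Cc1oc(-c2c(Br)cccc2Br)nc1CN1CCC(C(=O)NCCCN2C[C@H](C)C[C@H](C)C2)CC1`: 6500 nM

Both compounds were tested in an ADME assay on Huh7.5.1 cells (Homo sapiens) for cytotoxicity, read by ATP content, with a stated time of 48 h; a higher number here means that more compound is tolerated, a lower number that less compound is tolerated. Compound 2 gives the lower of the two numbers, so less of it is tolerated by the cells. In this assay compound 1 gives 21300 nM, a higher number than compound 2, and the gap between them is beyond the usual scatter.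

Compound 3, `Cc1cccc(C)c1-c1nc(CN2CCC(C(=O)NCCCN3C[C@H](C)C[C@H](C)C3)CC2)c(C)o1`, has not yet been measured in this assay. Going by the values given here, it differs from compound 2 in one place: 2,6-dimethylphenyl in place of 2,6-dibromophenyl on an aromatic carbon No measured pair shows this exact change, so no step size is known for it, and the expectation below rests only on the two numbers in hand.

Compound 1, which also carries methyl on the phenyl ring, gives the higher number, and compound 3 is expected to move in the same direction, a moderate rise in tolerated concentration, as the step of a 1.8-fold higher number from compound 2 to compound 3 (0.27 log units; within the scatter). Compound 3 is thus estimated at 12000 nM, with a range of 4000 nM to 40000 nM.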

Compound 3, half-maximal cytotoxic concentration: 21000 nM
Compound 3: the middle estimate sits 1.8-fold (0.24 log units) below what was measured, and the stated range covers the measured number.
By their numbers in this assay, from the lowest: compound 2; then compounds 3 and 1 (each within the scatter of the next).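

Going by these compounds alone, compound 1 and compound 2 differ in more than one place, so they could not isolate the aryl group; here, in this assay, placing 2,6-dimethylphenyl in position of 2,6-dibromophenyl on the aromatic carbon of the five-membered ring gives a 3.2-fold higher number from compound 2 to compound 3 (0.51 log units; beyond the scatter) and this is the first measured size for that single change. The two groups match in what can be counted for them, with the same number of heavy atoms, one six-membered aromatic ring of carbon only, no hydrogen-bond donors or acceptors and no net charge, and the one difference in that count is that bromine gives way to carbon. No measurement shown here accounts for the rise in tolerated concentration.

The compounds shown leave open how a 2,6-dichlorophenyl group, a 2,6-dimethoxyphenyl group or a plain phenyl ring would fare at this place. Within the data shown here, they also leave open whether the same step would appear with a different amine at the far end of the chain, such as the one carried by compound 1.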